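The source may report more compounds than this note shows. Statements on the series, on what has been measured and on what is new or still open speak of the compounds shown alone.

Of the compounds shown here, three share one core and have been measured in an ADME assay on microsomes from liver (Mus musculus, strain CD-1) for metabolic stability, read by LC-MS, tested at 2 uM; on this read-out higher numbers stand for a longer-lived compound and lower numbers for a shorter-lived compound. Compound 1 `CNS(=O)(=O)c1ccccc1Nc1cc(-c2ccc3ccn(C)c3c2)c2nccnc2c1` gives 0.2 h there, and compound 2 `CN(Cc1cncnc1)S(=O)(=O)c1ccccc1Nc1cc(-c2ccc3ccn(C)c3c2)c2nccnc2c1` gives 0.2 h. Among the measured compounds shown here, the one change between them, (pyrimidin-5-yl)methyl in place of hydrogen on a sulfonamide nitrogen, left the read-out unmoved: no change at the digits printed from compound 1 to compound 2 (within the scatter). Compound 3 `Cn1ccc2ccc(-c3cc(Nc4cnccc4C(=O)NCc4cncnc4)cc4nccnc34)cc21` gives 0.4 h in this assay, the top of the three numbers, though its gaps to compound 1 and to compound 2 both lie within the scatter.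

Compound 4 `CC(=O)N1CCC(NC(=O)c2ccncc2Nc2cc(-c3ccc4ccn(C)c4c3)c3nccnc3c2)C1` has not yet been measured in this assay. It differs from compound 3 in one place: 1-acetylpyrrolidin-3-yl in place of (pyrimidin-5-yl)methyl on an amide-type nitrogen. For the measured compounds named here, the only measured step that touches the (pyrimidin-5-yl)methyl group is the one from compound 1 to compound 2, where that group was added on a sulfonamide nitrogen and the number did not move. Going by the values given here, no measured pair shows an exchange on an amide-type nitrogen, and none shows 1-acetylpyrrolidin-3-yl at all, so the evidence for this step is thin. Because the step of no change at the digits printed from compound 1 to compound 2 (within the scatter) was flat, the expectation for compound 4 is a step of no change at the digits printed from compound 3 to compound 4 (within the scatter), that is, nothing beyond the scatter in this assay. Compound 4 is therefore estimated at 0.4 h, within a range from 0.2 h to 0.9 h.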

Compound 4, half-life: 0.667 h
Estimate against measurement, compound 4: 1.7-fold (0.22 log units) below; the range from low to high includes it.
By their numbers in this assay, from the lowest: compounds 1, 2, 3 and 4 (each within the scatter of the next, the first and the last beyond it).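

In this assay the position on the amide-type nitrogen now has a measured exchange of its own, and a 1.7-fold higher number from compound 3 to compound 4 (0.22 log units; within the scatter) shows that swapping (pyrimidin-5-yl)methyl for 1-acetylpyrrolidin-3-yl stays inside the usual scatter. Until now the (pyrimidin-5-yl)methyl group had been seen only as an addition on a sulfonamide nitrogen; this pair shows that, on the amide-type nitrogen, a six-membered aromatic ring with two hetero atoms can give way to a five-membered non-aromatic ring carrying an acetyl carbonyl without a step beyond that scatter. Nothing presented here offers a measured reason for this outcome.

The compounds shown leave open whether a free amine, such as pyrrolidin-3-yl without its acetyl, a carboxylic acid or a longer chain on the same amide-type nitrogen would also stay within the scatter of compound 3 or would carry the half-life beyond it. They also leave open whether 1-acetylpyrrolidin-3-yl on the sulfonamide nitrogen of compound 1 would give a step as small as this one.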